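Aryl substituent series toward compound 4

A few compounds are considered here, and "the series" means these few. Any claim that something is new, unique, unknown or untested is made for them only; others in the source may bear on it.

Compound 1 `CCCCc1ccc(-c2cc(=O)c3c(o2)C(CC)(CC)C(=O)C(CC)=C3O)cc1`, compound 2 `CCC1=C(O)c2c(oc(-c3ccc(OC(F)(F)F)cc3)cc2=O)C(CC)(CC)C1=O` and compound 3 `CCC1=C(O)c2c(oc(-c3ccc(CBr)cc3)cc2=O)C(CC)(CC)C1=O` share one core and differ only in the substituted phenyl sitting on an aromatic carbon of a six-membered aromatic ring with one oxygen, next to the ring oxygen. In a functional assay on KBVIN cells (Homo sapiens) for antiproliferative activity, read by sulforhodamine B assay, with a stated time of 3 days (on this read-out lower numbers stand for an effect already at smaller amounts and higher numbers for an effect only at larger amounts of compound), compound 1 gives 37 uM, compound 2 gives 9.95 uM and compound 3 gives 27.9 uM. Compound 3 thus holds the second highest of the three numbers: it stands nearest compound 1, as a 1.3-fold lower number from compound 1 to compound 3 (0.12 log units; within the scatter) shows, and furthest from compound 2, as a 2.8-fold higher number from compound 2 to compound 3 (0.45 log units; beyond the scatter) shows.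

Compound 4 `CCC1=C(O)c2c(oc(-c3ccc(OC)c(C)c3)cc2=O)C(CC)(CC)C1=O` continues from compound 3 by the change (4-methoxy-3-methylphenyl in place of 4-(bromomethyl)phenyl on an aromatic carbon). Among the measured compounds shown here, two measured steps bear on this. Placing an oxygen-linked group on the phenyl gave a 3.7-fold lower number from compound 1 to compound 2 (0.57 log units; beyond the scatter), the one step beyond the scatter toward lower numbers, whereas a 1.3-fold lower number from compound 1 to compound 3 (0.12 log units; within the scatter) stayed within the scatter. Compound 4 again carries an oxygen-linked group on the phenyl, so a modest move toward lower numbers in this assay is expected, about a 1.9-fold lower number from compound 3 to compound 4 (0.27 log units; within the scatter), though not the full size of the move seen for compound 2. Compound 4 is therefore estimated at 15 uM, with a range from 6 uM to 40 uM.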

Compound 4, concentration for half-maximal effect: 0.1 uM
Estimate against measurement, compound 4: 150-fold (2.18 log units) above, and the stated range ends above it.
By their numbers in this assay, from the lowest: compound 4; then compound 2; then compounds 3 and 1 (each within the scatter of the next).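

In this assay, among the compounds shown here, 4-methoxy-3-methylphenyl in place of 4-(bromomethyl)phenyl on this aromatic carbon gives a 280-fold lower number from compound 3 to compound 4 (2.45 log units; beyond the scatter), a large step that far exceeds the modest 3.7-fold lower number from compound 1 to compound 2 (0.57 log units; beyond the scatter), the biggest move among the earlier compounds. This position therefore responds much more strongly to the choice of substituted phenyl than butyl, trifluoromethoxy and bromomethyl suggested, and compound 4 now has the lowest number of the four, with its steps to compound 3 and compound 2 far apart in size. An oxygen-linked group on the phenyl is not enough on its own, since compound 2, with trifluoromethoxy, gives 9.95 uM, whereas compound 4 gives 0.1 uM.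

Nothing available on these compounds explains the size of this step. The compounds shown do not separate the methoxy from the methyl, so it remains open whether either group alone or only the two together give the low number, and how a dimethylamino group or an ethoxy group on the phenyl would read in this assay.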